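From compound 3 to compound 4: replacing the aromatic group

The source may report more compounds than this note shows. Statements on the series, on what has been measured and on what is new or still open speak of the compounds shown alone.

For the measured compounds named here, in an ADME assay on microsomes from liver (Rattus norvegicus) for metabolic stability, read by LC-MS, using NADPH, with a stated time of 60 min, tested at 0.1 uM (on this read-out higher numbers stand for a more stable compound and lower numbers for a less stable compound), compound 3 `Fc1ccc(Nc2cc3[nH]c(Nc4ccc(N5CCN(CC6CC6)CC5)cn4)nc3cn2)cc1F` gives 9%, the lowest of the three numbers so far. Compound 1 `Fc1ccc(Nc2cc3[nH]c(Nc4ccc(N5CCN(CC6CC6)CC5)cn4)nc3cn2)cc1C(F)(F)F` stands at 36% and compound 2 `Fc1ccc(Nc2cc3[nH]c(Nc4ccc(N5CCNCC5)cn4)nc3cn2)cc1F` at 73%.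

The next compound, compound 4 `FC1(F)CC(Nc2cc3[nH]c(Nc4ccc(N5CCN(CC6CC6)CC5)cn4)nc3cn2)C1`, carries 3,3-difluorocyclobutyl in place of 3,4-difluorophenyl on a nitrogen on an aromatic ring.

Going by the values given here, two measured steps bear on this change. The closer one, at the same aromatic group, is fluoro in place of trifluoromethyl, a modest step: a number 27 percentage points lower from compound 1 to compound 3 (beyond the scatter). The other is cyclopropylmethyl in place of hydrogen on an amine nitrogen in a ring, a large step: a number 64 percentage points lower from compound 2 to compound 3 (beyond the scatter). Compound 4 retains that cyclopropylmethyl group. Neither step replaces the whole aromatic ring, so the evidence is indirect.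

A modest rise, similar in size to the step at the aromatic group, is expected, and the estimated step is a number 19 percentage points higher from compound 3 to compound 4 (beyond the scatter). Compound 4 is estimated at 28%, with an expected range of 9% to 52%.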

Compound 4, percent of the compound remaining: 52%
Beside the measured number, compound 4's estimate is 24 percentage points below it, within the range that was stated.
By their numbers in this assay, from the lowest: compound 3; then compound 1; then compound 4; then compound 2.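

For the compounds shown here, the 3,3-difluorocyclobutyl group is the first non-aromatic group at this nitrogen on an aromatic ring, and in this assay replacing 3,4-difluorophenyl with it gives a number 43 percentage points higher from compound 3 to compound 4 (beyond the scatter) with the cyclopropylmethyl group retained. Replacing 4-fluoro-3-(trifluoromethyl)phenyl gives a number 16 percentage points higher from compound 1 to compound 4 (beyond the scatter) as well, so in both pairs shown the compound with 3,3-difluorocyclobutyl carries the higher number. Nothing available gives a measured reason for either step.

The compounds shown leave open whether the rise follows the loss of the aromatic ring, the ring size or the fluorine atoms, which a plain cyclobutyl or a cyclohexyl on this nitrogen would help separate. Also open, from the compounds shown here alone, is what 3,3-difluorocyclobutyl gives with hydrogen in place of cyclopropylmethyl on the amine nitrogen in the ring.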